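This account rests on a few compounds, and the source may have more. Where it says the series, first, only, none or still open, it means among the compounds named here.

Compound 1 `CCCCSc1nc(Cc2c(F)cccc2Cl)cc(=O)[nH]1` opens the series. In an ADME assay on MT4 cells (Homo sapiens) for activation, read by MTT assay (a lower number here means that less compound is tolerated, a higher number that more compound is tolerated), compound 1 gives only a limit, > 76000 nM. Compound 2 `CCCCSc1nc(C(C)c2c(F)cccc2Cl)cc(=O)[nH]1` likewise gives only a limit in this assay, > 73000 nM. The change methyl in place of hydrogen on a saturated chain carbon bound to two aromatic carbons therefore yields a step that the two limits leave unreadable from compound 1 to compound 2. Compound 3 `Cc1c(O)nc(SC(C)C)nc1C(C)c1c(F)cccc1F` differs from compound 1 in more than one place, and the difference between the two cores is not broken down here. In this assay compound 3 gives only a limit, > 3000 nM. Compound 4 `CCC(C)Sc1nc(O)c(C)c(C(C)c2c(F)cccc2F)n1` carries methyl in place of hydrogen on a saturated chain carbon, two bonds along the chain from a sulfur, the same kind of change as from compound 1 to compound 2, though the place here is two bonds along the chain from a sulfur rather than bound to two aromatic carbons. For compound 4 the expected step is a step that the limit leaves unreadable from compound 3 to compound 4, which rests on compound 3 sitting at the limit of > 3000 nM in this assay, at which 1 of the 3 values shown sits, and on the unreadable a step that the two limits leave unreadable from compound 1 to compound 2. Compound 4 is thus estimated at 30000 nM, between 5000 nM and 100000 nM.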

Compound 4, half-maximal cytotoxic concentration: > 3000 nM
Compound 4 ended at the assay's limit (the forecaster's own chance of this, stated with the estimate: 65%); the middle value lies beyond the limit too.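

In this assay compound 3 and compound 4 both give only limits, so no step can be read between them. The compounds shown leave open where any true half-maximal cytotoxic concentration lies, and whether isopropyl to sec-butyl changes it.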